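Removing the Amine Methyl from a Fused Bicyclic Amino Alcohol

The source may hold more compounds than are shown below. What is called first, only, known or untested is meant among the compounds shown, and "the series" means these compounds.

Compound 1 `CN1CC[C@@H]2CC[C@H](O)C[C@@H]21`: in an assay on HEK293 cells for displacement of a labelled ligand from Neuronal acetylcholine receptor; alpha4/beta2 (Rattus norvegicus), with a stated time of 4 h (a lower number here means a stronger inhibitor, a higher number a weaker inhibitor), compound 1 gives > 300000 nM, which is a limit of the assay and not a number.
Compound 2 `O[C@H]1CC[C@H]2CCN[C@H]2C1`: in this assay compound 2 gives > 300000 nM, again a limit of the assay.
Going by the values given here, compound 3 `CN1CCC2=CC[C@H](O)C[C@@H]21`: in this assay compound 3 gives 300000 nM, the only number among the three.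

Compound 2 differs from compound 1 by hydrogen in place of methyl on an amine nitrogen in a ring. The step that the two limits leave unreadable from compound 1 to compound 2 cannot be read, since both values rest on (the limit of > 300000 nM in this assay, at which 2 of the 3 values shown sit). Compound 3 carries a different core from compound 1; the difference between the two cores is not broken down here.

Compound 4 `O[C@H]1CC=C2CCN[C@H]2C1` has not yet been measured. It differs from compound 3 by hydrogen in place of methyl on an amine nitrogen in a ring. This is the same kind of change as that from compound 1 to compound 2, though the earlier place is also described as two ring bonds from the ring atom that bears a fused ring, which is not said of this one.

Since that earlier change left no readable step, compound 4 is expected to give about 300000 nM in this assay, with the estimated range 100000 nM to 1000000 nM. The estimated step of no change at the digits printed from compound 3 to compound 4 (within the scatter) is expected to be small, and a limit rather than a number is quite possible.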

Compound 4, inhibition constant: > 300000 nM
Compound 4 gave a limit, no number; the forecaster's own chance of this, stated with the estimate: 65%; the middle value lies on the limit itself.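

In this assay compound 4 gives > 300000 nM, which is a limit of the assay and not a number. Putting hydrogen in place of methyl on the ring amine nitrogen of this core gives a number no lower from compound 3 to compound 4 (the limit leaves the size open), and the size of this step cannot be read, any more than that of the same change on the core of compound 1, since the values pile up at one end of the scale: the limit of > 300000 nM in this assay, at which 3 of the 4 values shown sit. Going by these compounds alone, this shows only that the change brought no readable number on either core; it does not show that the change has the same size on both, so nothing can be said about how well it carries from one core to the other.

The compounds shown leave open whether a longer chain, such as ethyl or benzyl, on the same nitrogen would give a readable number in this assay. They also leave open what an amine or a carboxylic acid in place of the hydroxyl group would do.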